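Ethylsulfanyl for hydroxy on the chain of compound 1

The source may hold more compounds than are shown below. What is called first, only, known or untested is meant among the compounds shown, and "the series" means these compounds.

Compound 1 `CN1CCN(c2nc3ccccc3n2CCO)CC1` gives 410 nM in a functional assay on ileum for inhibition of histamine H1 receptor (Cavia porcellus) (on this read-out higher numbers stand for weaker inhibition and lower numbers for stronger inhibition), and stands highest of the two numbers measured; compound 2 `CCOCCn1c(N2CCCN(Cc3ccccc3)CC2)nc2ccccc21` gives 15 nM in this assay, a lower number beyond the scatter. Among the compounds with values here, no single-point step between measured compounds is available. Compound 3 `CCSCCn1c(N2CCN(C)CC2)nc2ccccc21` differs from compound 1 by ethylsulfanyl in place of hydroxy on a saturated chain carbon, two bonds along the chain from an aromatic nitrogen. For compound 3 a moderate lowering of the number is expected, beyond the scatter, estimated as a 2.7-fold lower number from compound 1 to compound 3 (0.44 log units; beyond the scatter). Compound 3 is accordingly expected at 150 nM, within 50 nM to 600 nM.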

Compound 3, half-maximal inhibitory concentration: 19 nM
For compound 3 the middle estimate is 7.9-fold (0.90 log units) above the measured one; measured number below the stated range.
By their numbers in this assay, from the lowest: compounds 2 and 3 (each within the scatter of the next); then compound 1.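

Ethylsulfanyl in place of hydroxy on the chain gives a 22-fold lower number from compound 1 to compound 3 (1.33 log units; beyond the scatter) in this assay, so this end of the chain strongly affects the read-out while the rest of compound 1 stays unchanged. The change removes the hydrogen-bond donor and adds carbon and sulfur together, and this single pair cannot separate those contributions. Nothing available accounts for the size of the step.

Open, on these data alone, is how a shorter methylsulfanyl, an ethoxy group on this same core, or a terminal amine or carboxylic acid on this chain would read.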